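A few compounds are considered here, and "the series" means these few. Any claim that something is new, unique, unknown or untested is made for them only; others in the source may bear on it.

Working notes on the series. Compound 1 `O=S(=O)(c1cccc(Cl)c1)n1ccc2c(N3CCNCC3)cccc21` is the reference point: in an assay on HeLa cells for displacement of a labelled ligand from 5-hydroxytryptamine receptor 6 (Homo sapiens) (a lower number here means a stronger inhibitor, a higher number a weaker inhibitor), compound 1 gives 0.251 nM, the lowest of the two numbers obtained so far. Going by the values given here, its only measured neighbour, compound 2 `O=S(=O)(c1ccc(Cl)cc1)n1ccc2c(N3CCNCC3)cccc21`, gives 2 nM in this assay, and the step is an 8.0-fold higher number from compound 1 to compound 2 (0.90 log units; beyond the scatter). Among the compounds with values here, that step concerns the chlorophenyl on the sulfonyl sulfur and is the only change measured in this set.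

Compound 3 `O=S(=O)(c1cccc(Cl)c1)n1cc(Cl)c2c(N3CCNCC3)cccc21` is still to be measured. Relative to compound 1 the change is chloro in place of hydrogen on an aromatic carbon. Within the data shown here, no measured step touches this aromatic carbon, so there is no direct precedent; the step from compound 1 to compound 2 shows only that the series is sensitive to a chlorine's position elsewhere. With the sulfonyl part kept as in compound 1, the expectation is a step from compound 1 to compound 3 of about a 1.4-fold higher number from compound 1 to compound 3 (0.14 log units; within the scatter), not clearly beyond the scatter. Compound 3 is therefore expected to give about 0.35 nM in this assay, within 0.08 nM to 1.5 nM.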

Compound 3, inhibition constant: 0.316 nM
Estimate against measurement, compound 3: 1.1-fold (0.04 log units) above; the range from low to high includes it.
By their numbers in this assay, from the lowest: compounds 1 and 3 (each within the scatter of the next); then compound 2.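

Chloro in place of hydrogen on this aromatic carbon, two ring bonds from the ring nitrogen and two ring bonds from the ring atom that bears a large group, is accepted in this assay with the sulfonyl part kept as in compound 1: the step is a 1.3-fold higher number from compound 1 to compound 3 (0.10 log units; within the scatter) and gives the series its first reading at this position. The earlier step, an 8.0-fold higher number from compound 1 to compound 2 (0.90 log units; beyond the scatter), showed sensitivity to where the chlorine sits on the chlorophenyl on the sulfonyl sulfur, whereas this added chlorine on the shared core leaves compound 3 within the scatter of compound 1. Nothing available bears on the reason for this result.

From the compounds shown here alone, whether this aromatic carbon also accepts methyl, an amine or a carboxylic acid remains open. Also open, going by these compounds, is whether the chloro step stays within the scatter when the sulfonyl sulfur carries the 4-chlorophenyl of compound 2.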